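This account rests on a few compounds, and the source may have more. Where it says the series, first, only, none or still open, it means among the compounds named here.

Measured so far in a functional assay, read by fluorescence and spectrophotometry, with a stated time of 1 h; a higher number here means that more compound is needed for the effect, a lower number that less compound is needed
compound 1 `CCCCCCS(=O)(=O)/C=C/c1ccc(O)c(O)c1` gives 7300 nM
compound 2 `CCCCCCCCCCS(=O)(=O)/C=C/c1ccc(O)c(O)c1` gives 6800 nM
compound 3 `C=CCCCCCS(=O)(=O)/C=C/c1ccc(O)c(O)c1` gives 7100 nM

Compound 3 stands within the scatter of the other two, with a 1.0-fold lower number from compound 1 to compound 3 (0.01 log units; within the scatter) and a 1.0-fold higher number from compound 2 to compound 3 (0.02 log units; within the scatter) as the measured steps. The next step leads to compound 4 `O=S(=O)(/C=C/c1ccc(O)c(O)c1)CCCC1CCCCC1` and reads cyclohexyl in place of but-3-en-1-yl on a saturated chain carbon, three bonds along the chain from a sulfonyl sulfur in full: cyclohexyl in place of but-3-en-1-yl on a saturated chain carbon, three bonds along the chain from a sulfonyl sulfur.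

The measured steps bearing on this change all lie in the chain: the two above, plus a 1.1-fold lower number from compound 1 to compound 2 (0.03 log units; within the scatter) as the third. None of them leaves the scatter, so changes in the chain have so far left the number in this assay where it was. Within the data shown here, no compound with a ring on the chain has been measured, so the ring itself is untested and the range is kept wide.

No step beyond the scatter is expected, and the estimated step is a 1.0-fold lower number from compound 3 to compound 4 (0.01 log units; within the scatter) in size. For compound 4 the expected value is 7000 nM within an estimated range from 3500 nM to 13000 nM.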

Compound 4, half-maximal effective concentration: 7900 nM
The estimate for compound 4 lay 1.1-fold (0.05 log units) below the measured number; the measured number falls inside the stated range.
By their numbers in this assay, from the lowest: compounds 2, 3, 1 and 4 (each within the scatter of the next).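

In this assay, cyclohexyl on a saturated chain carbon, three bonds along the chain from a sulfonyl sulfur, leaves the number within the scatter, with a 1.1-fold higher number from compound 3 to compound 4 (0.05 log units; within the scatter) against the but-3-en-1-yl chain. The comparisons with the open saturated chains read the same: a 1.1-fold higher number from compound 1 to compound 4 (0.03 log units; within the scatter) for cyclohexyl in place of propyl and a 1.2-fold higher number from compound 2 to compound 4 (0.07 log units; within the scatter) for cyclohexyl in place of heptyl. A six-membered non-aromatic ring of carbon only, absent from the earlier compounds, therefore fits the flat picture at this position, and no supporting measurement accounts for that flatness.

From the compounds shown here alone, whether an amine, a carboxylic acid or a phenyl ring at this place would take the number beyond the scatter stays open. Going by these compounds, with all four compounds within the scatter of one another, it is also open which change to the chain, if any, moves this number.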